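The compounds below may be only part of what the source reports. "The series", "measured", "known", "first", "only" and "open" are said of these compounds alone.

Measured so far:
compound 1 `Cc1cccc(C#Cc2nc3c(s2)C(=O)NCC3)c1` — > 10000 nM
compound 2 `CC(=O)N1CCc2nc(C#Cc3ccccc3)sc2C1` — 90 nM

In an assay on HEK293 cells for negative allosteric modulation of metabotropic glutamate receptor 5 (Homo sapiens), read by FLIPR, with a stated time of 1 h (a lower number here means a stronger inhibitor, a higher number a weaker inhibitor), compound 1 returns only a limit, > 10000 nM, which is the limit of > 10000 nM in this assay, at which 1 of the 2 values shown sits. Going by the values given here, compound 2 is the sole compound with a number, 90 nM in this assay. Compound 3 `O=S(=O)(C1CC1)N1CCc2nc(C#Cc3ccccc3)sc2C1` differs from compound 2 by cyclopropylsulfonyl in place of acetyl on an amine nitrogen in a ring. Among the compounds with values here, no measured pair of this kind exists, so the change in this assay is expected to be modest, if anything toward a weaker inhibitor, and may stay within the scatter. Compound 3 is estimated at 150 nM, between 40 nM and 600 nM. The expected step is a 1.7-fold higher number from compound 2 to compound 3 (0.22 log units; within the scatter).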

Compound 3, half-maximal inhibitory concentration: 34 nM
Beside the measured number, compound 3's estimate is 4.4-fold (0.64 log units) above it; the measured number lies below the stated range.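

In this assay, going by these compounds alone, cyclopropylsulfonyl in place of acetyl on the amine nitrogen in a ring gives a 2.6-fold lower number from compound 2 to compound 3 (0.42 log units; beyond the scatter) and is the first readable step. This position therefore accepts a group of 6 heavy atoms with a sulfonyl in place of the carbonyl, and the inhibitor gets stronger rather than weaker. Nothing measured here accounts for the step.

Open, as far as these compounds go, is whether the sulfonyl or the cyclopropyl ring carries the gain; methylsulfonyl and cyclopropylcarbonyl on this nitrogen would separate them. From the compounds shown here alone, a free secondary amine there also remains open.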